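Moving the Piperidine Ring Out Along the Chain

The source may report more compounds than this note shows. Statements on the series, on what has been measured and on what is new or still open speak of the compounds shown alone.

Measured so far:
compound 1, `c1ccc2c(c1)CN[C@@H](CN(CC1CCNCC1)[C@H]1CCCc3cccnc31)C2` — 86%
compound 2, `CC(C)N1CCN(CCCN(C[C@H]2Cc3ccccc3CN2)[C@H]2CCCc3cccnc32)CC1` — 46%
compound 3, `c1ccc2c(c1)CN[C@@H](CN(CCCCN1CCNCC1)[C@H]1CCCc3cccnc31)C2` — 82%

In an ADME assay on microsomes from liver (Homo sapiens) for metabolic stability, read by LC-MS, with a stated time of 10 min, tested at 0.5 uM (a lower number here means that less of the compound is left, a higher number that more of the compound is left), compound 3 stands second highest of the three numbers. Its nearest neighbour is compound 1, and the step of a number 4 percentage points lower from compound 1 to compound 3 (within the scatter) lies within the scatter, so the two cannot be told apart. Its furthest neighbour is compound 2, and the step of a number 36 percentage points higher from compound 2 to compound 3 (beyond the scatter) is large and well beyond the scatter.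

Compound 4, `c1ccc2c(c1)CN[C@@H](CN(CCC1CCNCC1)[C@H]1CCCc3cccnc31)C2`, has not yet been measured. It differs from compound 3 in one place: piperidin-4-yl in place of 2-(piperazin-1-yl)ethyl on a saturated chain carbon, two bonds along the chain from an amine nitrogen. For the measured compounds named here, two measured steps bear on this. The step of a number 4 percentage points lower from compound 1 to compound 3 (within the scatter) traded piperidin-4-yl for 3-(piperazin-1-yl)propyl and stayed within the scatter. Going by the values given here, the step of a number 36 percentage points higher from compound 2 to compound 3 (beyond the scatter) shows that the one large change came with 4-isopropylpiperazin-1-yl, a ring with no hydrogen-bond donor. Compound 4, like compound 1 and compound 3, keeps a ring with one hydrogen-bond donor, so for compound 4 the expected step is a number 2 percentage points higher from compound 3 to compound 4 (within the scatter), that is, nothing beyond the scatter. The estimate for compound 4 in this assay is 84%, with a range from 70% to 95%.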

Compound 4, percent of the compound remaining: 66%
Beside the measured number, compound 4's estimate is 18 percentage points above it; the whole stated range lies above it.
By their numbers in this assay, from the lowest: compound 2; then compound 4; then compounds 3 and 1 (each within the scatter of the next).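

In this assay, a ring with a hydrogen-bond donor is no longer enough to keep the number high: swapping 2-(piperazin-1-yl)ethyl for piperidin-4-yl gives a number 16 percentage points lower from compound 3 to compound 4 (beyond the scatter), so the identity of the ring at this place matters even when the donor stays. The length of the link to the piperidine ring matters too, since (piperidin-4-yl)methyl in place of piperidin-4-yl, on a saturated chain carbon bound to an amine nitrogen, gives a number 20 percentage points lower from compound 1 to compound 4 (beyond the scatter). The lowest number still belongs to the compound with the 4-isopropylpiperazin-1-yl ring, with a number 20 percentage points higher from compound 2 to compound 4 (beyond the scatter), so compound 4 falls in the middle of the series rather than joining either end.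

No measurement offered here explains why these changes move the amount of compound left. The compounds shown leave open whether a longer chain such as 3-(piperidin-4-yl)propyl would lower the number further, and whether an isopropyl group on the nitrogen of the piperidine ring would have the same effect as the one on the piperazine ring of compound 2.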